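The source may hold more compounds than are shown below. What is called first, only, known or untested is meant among the compounds shown, and "the series" means these compounds.

Measured so far:
Compound 1 `CCOC(=O)c1c(-c2cccc(-c3ccccc3)c2)[nH]c2cc(OC)c(OC)cc2c1=O`: in an ADME assay on BJ cells (Homo sapiens) for cytotoxicity, read by luminescence, with a stated time of 72 h (a lower number here means that less compound is needed, a higher number that more compound is needed for the effect), compound 1 gives > 21500 nM, which is a limit of the assay and not a number.
Compound 2 `CCOC(=O)c1c(-c2cccc(OC)c2)[nH]c2cc(OC)c(OC)cc2c1=O`: in this assay compound 2 gives > 21500 nM, again a limit.
Compound 3 `CCOC(=O)c1c(-c2cccc(-c3ccccc3)c2)[nH]c2cc(Cl)c(Cl)cc2c1=O`: in this assay compound 3 gives > 21500 nM, also a limit.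

The change from compound 1 to compound 2 is methoxy in place of phenyl on an aromatic carbon. Its step, a step that the two limits leave unreadable from compound 1 to compound 2, cannot be sized, because both compounds sit at the limit of > 21500 nM in this assay, at which 3 of the 3 values shown sit. Compound 3 carries a different core from compound 1; the difference between the two cores is not broken down here.

Compound 4 `CCOC(=O)c1c(-c2cccc(OC)c2)[nH]c2cc(Cl)c(Cl)cc2c1=O` is not yet measured in this assay. It differs from compound 3 by methoxy in place of phenyl on an aromatic carbon, the same change as that from compound 1 to compound 2, with the place described in the same words. No readable step is available to carry over, since every measured value in the series is a limit. The step from compound 3 to compound 4 is therefore expected to be a step that the limit leaves unreadable from compound 3 to compound 4, resting only on (the limit of > 21500 nM in this assay, at which 3 of the 3 values shown sit). Compound 4 is estimated at 40000 nM, expected between 15000 nM and 150000 nM, most likely reported once more as a limit.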

Compound 4, half-maximal effective concentration: > 21500 nM
Compound 4 gave a limit, no number; the forecaster's own chance of this, stated with the estimate: 85%; the middle value is on the limit's open side.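

Compound 3 and compound 4 both stand as limits and not numbers in this assay, so no step can be read between them: the limit of > 21500 nM in this assay, at which 4 of the 4 values shown sit.

The compounds shown leave open whether methoxy in place of phenyl on an aromatic carbon, or the difference between the cores, changes the read-out in this assay at all.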